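Chain extension by one carbon on the phenoxy tether

The source may hold more compounds than are shown below. What is called first, only, known or untested is meant among the compounds shown, and "the series" means these compounds.

Going by the values given here, compound 3 `O=C(O)CCC[C@H](O)[C@@H](/C=C\CCCCCCCCOc1ccccc1)Sc1ccc(C(=O)O)cc1` gives 631 nM in an assay on membranes from lung for binding affinity to cysteinyl leukotriene receptor 1 (Cavia porcellus) (on this read-out lower numbers stand for stronger inhibition and higher numbers for weaker inhibition), the second highest of the three numbers so far. Compound 1 `O=C(O)CCC[C@H](O)[C@@H](/C=C\CCCCCc1ccccc1)Sc1ccc(C(=O)O)cc1` gives 20000 nM; compound 2 `O=C(O)CCC[C@H](O)[C@@H](/C=C\CCCCCCCCCc1ccccc1)Sc1ccc(C(=O)O)cc1` gives 251 nM. Lengthening the tail drives the series: an 80-fold lower number from compound 1 to compound 2 (1.90 log units; beyond the scatter) and a 32-fold lower number from compound 1 to compound 3 (1.50 log units; beyond the scatter), both large. Between the two long tails the gap is modest, a 2.5-fold higher number from compound 2 to compound 3 (0.40 log units; beyond the scatter).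

Compound 4 `O=C(O)CCC[C@H](O)[C@@H](/C=C\CCCCCCCCCOc1ccccc1)Sc1ccc(C(=O)O)cc1` differs from compound 3 by phenoxymethyl in place of phenoxy on a saturated chain carbon, eight bonds along the chain from a double-bonded chain carbon. Among the compounds with values here, no step of exactly this kind has been measured, but the steps from compound 1 onward show that adding length to the tail lowers the number, while the step from compound 2 to compound 3 shows that the longer benzyl-terminated chain of compound 2 sits lower than compound 3. Compound 4 is therefore expected to move a modest step downward in this assay, a 2.1-fold lower number from compound 3 to compound 4 (0.32 log units; beyond the scatter), toward the value of compound 2 and not beyond the lowest number seen so far. Compound 4 is estimated at 300 nM, with a range of 100 nM to 1000 nM.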

Compound 4, inhibition constant: 316 nM
Compound 4: middle estimate off by 1.1-fold (0.02 log units), on the low side; low and high end bracket the measured number.
By their numbers in this assay, from the lowest: compounds 2, 4 and 3 (each within the scatter of the next, the first and the last beyond it); then compound 1.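

In this assay, phenoxymethyl in place of phenoxy on a saturated chain carbon, eight bonds along the chain from a double-bonded chain carbon, gives a 2.0-fold lower number from compound 3 to compound 4 (0.30 log units; within the scatter), so one more carbon on the phenoxy tether cannot be told from no change. The phenoxy-ended and phenyl-ended tails, which were apart beyond the scatter in the earlier pair, are not resolved here, with a 1.3-fold higher number from compound 2 to compound 4 (0.10 log units; within the scatter) for phenoxy in place of phenyl, nine bonds along the chain from a double-bonded chain carbon. The large step from the short tail holds for this tether as well, at a 63-fold lower number from compound 1 to compound 4 (1.80 log units; beyond the scatter), and no measurement at hand accounts for any of these steps.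

From the compounds shown here alone, whether a longer chain than 4-phenoxybutyl leaves the number in this range remains open. So does whether an amine or a carboxylic acid at the tail end, in place of the phenoxy, would hold it there.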